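The compounds below may be only part of what the source reports. "The series", "measured", "known", "first", "only" and "open" are said of these compounds alone.

Among the compounds with values here, in a functional assay on HCT-116 cells (Homo sapiens) for inhibition, read by resazurin assay, with a stated time of 24 h (a higher number here means a weaker inhibitor of growth, a lower number a stronger inhibitor of growth), compound 1 (`NC(=O)c1ccccc1Nc1cccc(-c2ccccc2)c1`) gives 43000 nM and compound 2 (`NC(=O)c1ccccc1Nc1cccc(Oc2ccccc2)c1`) gives 50000 nM, so compound 2 stands level with its only neighbour. Within the data shown here, the single measured step, a 1.2-fold higher number from compound 1 to compound 2 (0.07 log units; within the scatter), exchanged one ring-bearing group for another. Compound 3 (`NC(=O)c1ccccc1Nc1cccc(/C=C/C(=O)O)c1`) differs from compound 2 by 2-carboxyethenyl in place of phenoxy on an aromatic carbon. The new group, 2-carboxyethenyl, has no ring, so that small step is only a weak guide, and no change beyond the scatter can be firmly expected. The expected step is a 1.2-fold higher number from compound 2 to compound 3 (0.08 log units; within the scatter). Compound 3 is estimated at 60000 nM, with an expected range of 20000 nM to 150000 nM.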

Compound 3, concentration for 50% growth inhibition: > 100000 nM
Compound 3: a limit, no number; the forecaster's own chance of this, stated with the estimate: 25%; middle value at least 1.6-fold (0.22 log units) from the limit.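

In this assay compound 3 reads > 100000 nM, which is a limit of the assay and not a number. The change gives an at least 2.0-fold higher number from compound 2 to compound 3 (0.30 log units; that floor lies within the scatter) and an at least 2.3-fold higher number from compound 1 to compound 3 (0.36 log units; beyond the scatter), so only against the phenyl compound does this ringless group show a loss of growth inhibition beyond the scatter, which the swap between the two ring-bearing groups did not show. The full size of that loss stays hidden: the limit of > 100000 nM in this assay, at which 1 of the 3 values shown sits.

On these data alone, whether losing the ring or bringing in the carboxylic acid counts for more stays open. An ethyl chain or an amine at this place, with neither ring nor acid, would help separate the two.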